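Hydroxy Added to the Chloroacetyl Urea of Compound 3

The compounds below may be only part of what the source reports. "The series", "measured", "known", "first", "only" and "open" are said of these compounds alone.

Compound 3 `CCCCCc1cccc(NC(=O)NC(=O)CCl)c1` gives 8400 nM in a functional assay on HT-29 cells (Homo sapiens) for antiproliferative activity, with a stated time of 48 h (a lower number here means a stronger inhibitor, a higher number a weaker inhibitor), the lowest of the three numbers recorded: compound 2 `CCCCC(O)c1cccc(NC(=O)NCCCCl)c1` gives 19000 nM and compound 1 `CCCCCc1cccc(NC(=O)NCCCCl)c1` gives 28000 nM. The step from compound 1 to compound 2 was a 1.5-fold lower number from compound 1 to compound 2 (0.17 log units; within the scatter), the step from compound 1 to compound 3 was a 3.3-fold lower number from compound 1 to compound 3 (0.52 log units; beyond the scatter). Compound 4 `CCCCC(O)c1cccc(NC(=O)NC(=O)CCl)c1` differs from compound 3 by hydroxy in place of hydrogen on a saturated chain carbon bound to an aromatic carbon and a saturated chain carbon. Among the measured compounds shown here, the only step that bears on this change, the one from compound 1 to compound 2, stayed within the scatter, so for compound 4 no step beyond the scatter is expected in this assay, the expected step from compound 3 being a 1.3-fold lower number from compound 3 to compound 4 (0.11 log units; within the scatter). Compound 4 is therefore estimated at 6500 nM, in a range from 3000 nM to 14000 nM.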

Compound 4, half-maximal inhibitory concentration: 10000 nM
Estimate against measurement, compound 4: 1.5-fold (0.19 log units) below; low and high end bracket the measured number.
By their numbers in this assay, from the lowest: compounds 3, 4, 2 and 1 (each within the scatter of the next, the first and the last beyond it).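

On the saturated chain carbon, the pentyl to 1-hydroxypentyl change gave a 1.2-fold higher number from compound 3 to compound 4 (0.08 log units; within the scatter) in this assay and so stayed within the scatter on a second core: the same change on two cores in this assay, a 1.5-fold lower number (0.17 log units; within the scatter) from compound 1 to compound 2 and a 1.2-fold higher number (0.08 log units; within the scatter) from compound 3 to compound 4, 1.8-fold (0.24 log units) apart, within the scatter of two such steps. The replacement of 3-chloropropyl by (chloromethyl)carbonyl on the amide-type nitrogen could now be read on the hydroxy core, where it gave a 1.9-fold lower number from compound 2 to compound 4 (0.28 log units; within the scatter) and, unlike on the core of compound 1, stayed within the scatter, though the two readings do not differ beyond it: the same change on two cores in this assay, a 3.3-fold lower number (0.52 log units; beyond the scatter) from compound 1 to compound 3 and a 1.9-fold lower number (0.28 log units; within the scatter) from compound 2 to compound 4, 1.8-fold (0.24 log units) apart, within the scatter of two such steps.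

From the compounds shown here alone, whether an amine or a methoxy group on this carbon would behave as hydroxy does remains open. So does the effect of a longer chain in place of pentyl.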